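Phenoxy substituent swap in the shared core: cyano for trifluoromethoxy

The compounds below may be only part of what the source reports. "The series", "measured", "known", "first", "only" and "open" are said of these compounds alone.

Measured so far in a functional assay on VCaP cells (Homo sapiens) for antiproliferative activity, read by propidium iodide staining, with a stated time of 96 h; on this read-out higher numbers stand for weaker inhibition and lower numbers for stronger inhibition (half-maximal inhibitory concentration):
- compound 1 `CC(O)(COc1cccc(C(F)(F)F)c1)C(=O)Nc1cccc(S(F)(F)(F)(F)F)c1` gives 22500 nM
- compound 2 `CC(O)(COc1ccc(OC(F)(F)F)cc1)C(=O)Nc1cccc(S(F)(F)(F)(F)F)c1` gives 20200 nM

On these numbers, compound 2 (20200 nM) stands level with compound 1 (22500 nM), the two values lying within the scatter of each other. Going by the values given here, the two compounds differ in more than one place, so no single-change step is available to guide the next entry.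

Compound 3 `CC(O)(COc1ccc(C#N)cc1)C(=O)Nc1cccc(S(F)(F)(F)(F)F)c1` keeps the core of compound 2 and has cyano in place of trifluoromethoxy on an aromatic carbon in the same place, para to a large group. The data hold no measured swap of either group, so the expectation rests only on the value of compound 2 (20200 nM). The step expected a 1.2-fold higher number from compound 2 to compound 3 (0.09 log units; within the scatter) is small, with at most a slight drift towards weaker inhibition and nothing beyond the scatter expected in this assay as the likeliest outcome.

The estimated value for compound 3 is 25000 nM within an expected range of 10000 nM to 60000 nM (an estimate only).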

Compound 3, half-maximal inhibitory concentration: 26600 nM
Compound 3: middle estimate off by 1.1-fold (0.03 log units), on the low side; measured number inside the range.
By their numbers in this assay, from the lowest: compounds 2, 1 and 3 (each within the scatter of the next).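

In this assay, going by these compounds alone, cyano in place of trifluoromethoxy on an aromatic carbon, para to a large group, gives a 1.3-fold higher number from compound 2 to compound 3 (0.12 log units; within the scatter) and so provides the first single-change reading at this position: the two groups stand level here, even though the entering group has fewer heavy atoms than the one that leaves. The broader exchange of 3-(trifluoromethyl)phenyl for 4-cyanophenyl on an oxygen on a saturated carbon gives a 1.2-fold higher number from compound 1 to compound 3 (0.07 log units; within the scatter), so this change of aryl group also leaves the number within the scatter, and the three compounds cannot be ranked from these values. No measurement at hand explains either result.

From the compounds shown here alone, it remains open whether an amine or a carboxylic acid on the same aromatic carbon would move the number beyond the scatter in this assay. Going by these compounds, it is equally open whether a change elsewhere in the shared core, such as a longer chain, would separate compounds that these aryl swaps leave level.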